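Compound 3 Trades Its 3-Bromopropyl Group for Selenium

This account rests on a few compounds, and the source may have more. Where it says the series, first, only, none or still open, it means among the compounds named here.

In a functional assay on HeLa cells (Homo sapiens) for antiproliferative activity, read by MTT assay, with a stated time of 48 h (a lower number here means a stronger inhibitor, a higher number a weaker inhibitor), compound 1 (`COc1ccc(N(C)c2ccnc(Cl)n2)cc1[N+](=O)[O-]`) carries nitro on an aromatic carbon and gives 4730 nM on the shared core. Compound 2 (`COc1ccc(N(C)c2ccnc(Cl)n2)cc1OCCCBr`) has 3-bromopropoxy in place of nitro and gives 307 nM as its reading, and that change is large (a 15-fold lower number from compound 1 to compound 2 (1.19 log units; beyond the scatter)). Compound 3 (`COc1ccc(N(C)c2ccnc(Cl)n2)cc1OCCCCCBr`) has (5-bromopentyl)oxy there and gives 7090 nM as its reading. It stands level with compound 1 within the scatter (a 1.5-fold higher number from compound 1 to compound 3 (0.18 log units; within the scatter)) and well above compound 2 (a 23-fold higher number from compound 2 to compound 3 (1.36 log units; beyond the scatter)).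

Compound 4 (`COc1ccc(N(C)c2ccnc(Cl)n2)cc1OCC[Se]C#N`) differs from compound 3 by a group of 3 heavy atoms (1 carbon, 1 nitrogen, 1 selenium; no ring) in place of a group of 4 heavy atoms (3 carbon, 1 bromine; no ring), on a saturated chain carbon, two bonds along the chain from an oxygen on an aromatic ring and has 1 triple bond outside aromatic rings. Among the compounds with values here, no measured compound holds selenium, so the measured steps bear on this change only indirectly. They show that the chain on this oxygen can move the number strongly, as compound 2 does with its large step (a 15-fold lower number from compound 1 to compound 2 (1.19 log units; beyond the scatter)), while compound 3 leaves it within the scatter of compound 1 (a 1.5-fold higher number from compound 1 to compound 3 (0.18 log units; within the scatter)). A large step towards a lower number in this assay is therefore expected, though with wide uncertainty. The estimated move is a 14-fold lower number from compound 3 to compound 4 (1.15 log units; beyond the scatter) in this assay. For compound 4 the expected value is 500 nM as a middle figure. The estimated range for compound 4 runs from 80 nM to 3000 nM in this assay.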

Compound 4, half-maximal inhibitory concentration: 436 nM
Compound 4: middle estimate off by 1.1-fold (0.06 log units), on the high side; measured number inside the range.
By their numbers in this assay, from the lowest: compounds 2 and 4 (each within the scatter of the next); then compounds 1 and 3 (each within the scatter of the next).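

In this assay, a low reading on this oxygen is no longer tied to a chain ending in bromine: with selenium on the chain, the reading stays within the scatter of the 3-bromopropoxy chain of compound 2 (a 1.4-fold higher number from compound 2 to compound 4 (0.15 log units; within the scatter)). The selenium-bearing chain also stands clearly apart from the (5-bromopentyl)oxy chain (a 16-fold lower number from compound 3 to compound 4 (1.21 log units; beyond the scatter)) and from the nitro group (an 11-fold lower number from compound 1 to compound 4 (1.04 log units; beyond the scatter)), so two of the three chains on this oxygen now give a large step away from nitro, with compound 3 as the one that goes against this. Nothing measured here accounts for these readings, and no supporting data bear on why this change has so large an effect.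

The compounds shown leave open whether the reading follows the selenium atom, the nitrile carbon and nitrogen attached to it, or the length of the chain. A sulfur atom in place of the selenium, a 2-bromoethoxy chain, or the same selenium group on a longer chain would be needed to separate these, and an amine at the chain end would test whether a group without selenium or bromine can give such a reading.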